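Series notes: methyl on the amine nitrogen of compound 2

The source may report more compounds than this note shows. Statements on the series, on what has been measured and on what is new or still open speak of the compounds shown alone.

Compound 2 `C=C=C(CN)Cc1ccccc1` gives 12 umol/kg in an assay on forebrain for inhibition of Monoamine oxidase (Mus musculus) (on this read-out lower numbers stand for an effect already at smaller amounts and higher numbers for an effect only at larger amounts of compound), the second highest of three numbers. Compound 3 `C=C=C(CN)Cc1ccc(Cl)cc1` gives 7 umol/kg, and a 1.7-fold lower number from compound 2 to compound 3 (0.23 log units; within the scatter). For the measured compounds named here, compound 1 `C=C=C(Cc1ccccc1)CN(C)C` gives 54 umol/kg, and a 4.5-fold lower number from compound 1 to compound 2 (0.65 log units; beyond the scatter) is the one step clearly beyond the scatter. Compound 4 `C=C=C(CNC)Cc1ccccc1` carries methyl in place of hydrogen on an amine nitrogen, that is amino to methylamino, aminomethyl to (methylamino)methyl. Going by the values given here, the only step bearing on this is a 4.5-fold lower number from compound 1 to compound 2 (0.65 log units; beyond the scatter), where removing both methyls from the nitrogen gave the lower number; putting one methyl back should undo part of that, so a modestly higher number is expected in this assay, near the edge of the scatter. Compound 4 is expected at 25 umol/kg, range 12 umol/kg to 50 umol/kg, an expected step of a 2.1-fold higher number from compound 2 to compound 4 (0.32 log units; beyond the scatter).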

Compound 4, dose for half-maximal effect: 11 umol/kg
Compound 4: middle estimate off by 2.3-fold (0.36 log units), on the high side, outside the stated range (below it).
By their numbers in this assay, from the lowest: compounds 3, 4 and 2 (each within the scatter of the next); then compound 1.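

In this assay the first methyl on the amine nitrogen does not separate the methylamino compound from the amino compound, as a 1.1-fold lower number from compound 2 to compound 4 (0.04 log units; within the scatter) shows. The separation from the dimethylamino compound appears only with the second methyl, since a 4.9-fold lower number from compound 1 to compound 4 (0.69 log units; beyond the scatter) is a step beyond the scatter for the removal of that one methyl. At this nitrogen, then, the effect of methyl is not additive across these compounds.

Still open, as far as these compounds go, is whether ethyl or a longer chain on this nitrogen stays with compound 4 or moves towards compound 1, and whether methylamino carries over to the chloro series of compound 3. No measurement here addresses why the two methyls differ.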